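A few compounds are considered here, and "the series" means these few. Any claim that something is new, unique, unknown or untested is made for them only; others in the source may bear on it.

Compound 1 `COC(=O)c1c[nH]c2cc(OCCOc3ccccc3)ccc2c1=O` in an ADME assay on J774 cells (Mus musculus) for cytotoxicity (a higher number here means that more compound is needed for the effect, a lower number that less compound is needed), gives > 20000 nM, which is a limit of the assay and not a number.
Compound 2 `CCCCc1cc2c(=O)c(C(=O)OC)c[nH]c2cc1OCCOc1ccccc1` in this assay gives > 20000 nM, again only a limit.
Compound 3 `O=c1cc[nH]c2cc(OCCOc3ccccc3)ccc12` in this assay gives > 20000 nM, again only a limit.

Compound 4 `CCCCc1cc2c(=O)cc[nH]c2cc1OCCOc1ccccc1` is not yet measured in this assay. It differs from compound 3 in one place: butyl in place of hydrogen on an aromatic carbon. The same change turns compound 1 into compound 2, where it reads as butyl in place of hydrogen on an aromatic carbon; the surroundings of the place are the same word for word, so it is the same change, not merely the same kind. Its size there is a step that the two limits leave unreadable from compound 1 to compound 2, and it stays unreadable because both values sit at the limit of > 20000 nM in this assay, at which 3 of the 3 values shown sit.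

The two cores differ in one counted place, from compound 1 to compound 3: hydrogen in place of methoxycarbonyl on an aromatic carbon. Going by the values given here, the step that goes with it is a step that the two limits leave unreadable from compound 1 to compound 3, likewise beyond reading, since every value so far stops at the same limit.

What can be expected for compound 4 rests only on this: the earlier step that the two limits leave unreadable from compound 1 to compound 2 gave no sign of cytotoxicity appearing, and all three values sit at the limit of > 20000 nM in this assay, at which 3 of the 3 values shown sit. For compound 4 the expected step is a step that the limit leaves unreadable from compound 3 to compound 4. Compound 4 is therefore estimated at 30000 nM in this assay, with a range from 15000 nM to 100000 nM, and most likely the assay will again report only a limit.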

Compound 4, half-maximal effective concentration: > 20000 nM
Compound 4: only a limit was reported; the forecaster's own chance of this, stated with the estimate: 85%; the middle value does not contradict the limit.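

In this assay compound 4 gives > 20000 nM, again a limit of the assay and not a number. Its steps from compound 3 and from compound 2 cannot be read, since every value stops at the same limit: the limit of > 20000 nM in this assay, at which 4 of the 4 values shown sit.

The compounds shown leave open at what concentration any of them harms these cells, and whether butyl or methoxycarbonyl changes that concentration at all.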